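Swapping Phenyl for Methyl on a Sulfonamide

This account rests on a few compounds, and the source may have more. Where it says the series, first, only, none or still open, it means among the compounds named here.

Measured so far in a functional assay on MCF7 cells (Homo sapiens) for cytotoxicity, read by MTT assay, with a stated time of 48 h; a higher number here means a weaker inhibitor, a lower number a stronger inhibitor:
Compound 1, `Nc1cc(NS(=O)(=O)c2ccccc2)cc(-c2cnc3[nH]cc(-c4ccncc4)c3c2)c1`, gives 8800 nM.
Compound 2, `Nc1ccc(-c2cnc3[nH]cc(-c4ccncc4)c3c2)cc1`, gives 7700 nM.

Both compounds share one core, and compound 2 carries only an amino group on its outer ring where compound 1 carries an amino group together with a phenylsulfonyl-substituted sulfonamide nitrogen. Going by the values given here, the two numbers lie within the usual scatter of repeated measurements, so compound 1 cannot be placed above or below compound 2 in this assay; it stands at the same level as the only other compound measured.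

Compound 3, `CS(=O)(=O)Nc1cc(N)cc(-c2cnc3[nH]cc(-c4ccncc4)c3c2)c1`, differs from compound 1 in one place: methyl in place of phenyl on a sulfonyl sulfur. Among the compounds with values here, no pair of measured compounds shows what this change does, so there is no measured step to lean on. With that absence of evidence, the expected step in this assay from compound 1 to compound 3 is none beyond the scatter, in neither direction.

Compound 3 is therefore expected to give about 8000 nM, with a likely range from 3000 nM to 25000 nM. This corresponds to an estimated step of a 1.1-fold lower number from compound 1 to compound 3 (0.04 log units; within the scatter).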

Compound 3, half-maximal inhibitory concentration: > 30000 nM
Compound 3: a limit, no number; the forecaster's own chance of this, stated with the estimate: 10%; middle value at least 3.7-fold (0.57 log units) away from the limit.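

Methyl in place of phenyl on a sulfonyl sulfur gives an at least 3.4-fold higher number from compound 1 to compound 3 (0.53 log units; beyond the scatter) in this assay, so what sits on this sulfur clearly affects the result, something the earlier compounds could not show. Going by these compounds alone, since a higher number means a weaker inhibitor, the phenyl form is the stronger member of this pair, although a single pair shows only this one change and establishes no wider trend. How much weaker compound 3 really is remains unknown, as its result is a limit of the assay and not a number: the limit of > 30000 nM in this assay, at which 1 of the 3 values shown sits.

The compounds shown do not reveal whether the aromatic ring itself matters or whether any group larger than methyl would do as well. An ethyl group or a longer carbon chain on the same sulfur would separate these two readings, while a benzyl group would show whether the ring still counts when it stands one carbon further from the sulfur.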